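Moving the Chlorine on a Cathepsin S Inhibitor

The compounds below may be only part of what the source reports. "The series", "measured", "known", "first", "only" and "open" are said of these compounds alone.

Compound 1 `CC(C)C[C@H](NC(=O)N1CCOCC1)C(=O)N[C@@H](C)C#N` and compound 2 `CC(C)C[C@H](NC(=O)N1CCOCC1)C(=O)N[C@H](C#N)COCc1ccccc1Cl` share one core and differ in a single place, where a hydrogen on compound 1 is replaced by a (2-chlorobenzyl)oxy group on a saturated chain carbon. In an assay for inhibition of cathepsin S (Homo sapiens) (a higher number here means a weaker inhibitor, a lower number a stronger inhibitor), compound 1 gives 142 nM, while compound 2 gives 9 nM. Among the measured compounds shown here, that is the step of a 16-fold lower number from compound 1 to compound 2 (1.20 log units; beyond the scatter), and it leaves compound 2 with the lowest number of the two measured so far, separated from compound 1 by that same gap.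

Compound 3 `CC(C)C[C@H](NC(=O)N1CCOCC1)C(=O)N[C@H](C#N)COCc1cccc(Cl)c1` keeps everything in compound 2 except the difference (3-chlorophenyl in place of 2-chlorophenyl on a saturated chain carbon bound to an oxygen on a saturated carbon). For the measured compounds named here, no measured step bears directly on this change: the only one available, a 16-fold lower number from compound 1 to compound 2 (1.20 log units; beyond the scatter), shows what the whole (2-chlorobenzyl)oxy group is worth, not what the exchange of 2-chlorophenyl for 3-chlorophenyl is worth. Going by the values given here, with only that indirect precedent, the expected step is small, a 1.3-fold higher number from compound 2 to compound 3 (0.12 log units; within the scatter), with no direction that can be called beyond the scatter. Compound 3 is therefore estimated to give 12 nM in this assay, within a range from 4 nM to 40 nM.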

Compound 3, half-maximal inhibitory concentration: 9 nM
Compound 3: middle estimate off by 1.3-fold (0.12 log units), on the high side; the range from low to high includes it.
By their numbers in this assay, from the lowest: compounds 2 and 3 (each within the scatter of the next); then compound 1.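

The exchange of 2-chlorophenyl for 3-chlorophenyl gives no change at the digits printed from compound 2 to compound 3 (within the scatter) in this assay, so the two chlorine placements compared here cannot be told apart in this test. The large step seen earlier, a 16-fold lower number from compound 1 to compound 2 (1.20 log units; beyond the scatter), therefore does not belong to the 2-chlorophenyl group alone: putting (3-chlorobenzyl)oxy in place of hydrogen gives a 16-fold lower number from compound 1 to compound 3 (1.20 log units; beyond the scatter), a step of the same printed size. Nothing available explains why these two groups match, and the result alone gives no reason for it.

The compounds shown leave open how much of the large step belongs to the chlorine itself, a question that a plain benzyl group without chlorine, or a fluorine or a methyl group in its place, would address in this assay. They also leave open whether the step would survive a longer chain between the oxygen and the aromatic ring, or an amine on that ring.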